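Changing the aryl group on a shared core

A few compounds are considered here, and "the series" means these few. Any claim that something is new, unique, unknown or untested is made for them only; others in the source may bear on it.

Compound 1 `Cc1cccc(/C=N/Nc2ncc3c(n2)n(C2CCCC2)c(=O)c(=O)n3C)c1` gives the highest number of the three measured compounds in a functional assay on PC-3 cells (Homo sapiens) for antiproliferative activity, read by MTT assay (a lower number here means a stronger inhibitor, a higher number a weaker inhibitor), namely 53600 nM. Compound 2 `Cn1c(=O)c(=O)n(C2CCCC2)c2nc(N/N=C/c3ccc(F)c(Cl)c3)ncc21` gives 8550 nM in this assay, and compound 3 `Cc1cc(C)c(/C=N/Nc2ncc3c(n2)n(C2CCCC2)c(=O)c(=O)n3C)c(C)c1` gives 13900 nM. Both changes to the aryl group brought the number down: a 6.3-fold lower number from compound 1 to compound 2 (0.80 log units; beyond the scatter) and a 3.9-fold lower number from compound 1 to compound 3 (0.59 log units; beyond the scatter). Compound 4 `COc1ccc(/C=N/Nc2ncc3c(n2)n(C2CCCC2)c(=O)c(=O)n3C)c(OC)c1` differs from compound 1 in one place: 2,4-dimethoxyphenyl in place of 3-methylphenyl on a carbon with a double bond to nitrogen. This change, like the two measured ones, replaces the 3-methylphenyl group with a differently substituted phenyl, so a modest drop in the number is expected, though neither measured step involved methoxy groups, which leaves the estimate uncertain. Compound 4 is therefore expected to give 18000 nM, between 6000 nM and 50000 nM, which would mean a step of a 3.0-fold lower number from compound 1 to compound 4 (0.47 log units; beyond the scatter).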

Compound 4, half-maximal inhibitory concentration: > 100000 nM
Compound 4 ended at the assay's limit; the forecaster's own chance of this, stated with the estimate: 10%; middle value at least 5.5-fold (0.74 log units) from the limit.
By their numbers in this assay, from the lowest: compounds 2 and 3 (each within the scatter of the next); then compound 1. At a limit, above all of these: compound 4.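

In this assay compound 4 stands at a limit of the assay, not at a measured number: the limit of > 100000 nM in this assay, at which 1 of the 4 values shown sits.

Replacing the 3-methylphenyl group therefore need not bring the number down, with an at least 1.8-fold higher number from compound 1 to compound 4 (0.27 log units; that floor lies within the scatter), a floor that does not separate these two compounds beyond the scatter. The gaps to the other two aryl groups are clearer, with an at least 7.1-fold higher number from compound 3 to compound 4 (0.85 log units; beyond the scatter) and an at least 11-fold higher number from compound 2 to compound 4 (1.06 log units; beyond the scatter), so among these four compounds the outcome depends on which substituted phenyl sits on this carbon.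

On these data alone, how far past the limit compound 4 lies remains unknown, as does the effect of a single methoxy group. The compounds shown also leave open how a phenyl carrying an amine or a carboxylic acid would behave.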